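This account rests on a few compounds, and the source may have more. Where it says the series, first, only, none or still open, it means among the compounds named here.

Measured so far in a functional assay on CHO cells for inhibition of metabotropic glutamate receptor 5 (Rattus norvegicus), read by FLIPR and calcium flux; on this read-out higher numbers stand for weaker inhibition and lower numbers for stronger inhibition:

Compound 1, `Cc1ccc2ccc(-c3cccc(C#N)c3)cc2n1`: 7.7 nM
Compound 2, `Cc1ccc2ccc(-c3cccc(C(F)(F)F)c3)cc2n1`: > 10000 nM, a limit of the assay
Compound 3, `Cc1ccc2ccc(-c3cccc(C(N)=O)c3)cc2n1`: > 10000 nM, a limit of the assay

Among the measured compounds shown here, compound 1 holds the only plain number in this assay, 7.7 nM. Compound 2 sits at a limit, > 10000 nM. Compound 3 likewise sits at a limit, > 10000 nM. Both measured steps exchange the cyano of compound 1 for another group: an at least 1200-fold higher number from compound 1 to compound 2 (3.11 log units; beyond the scatter), and an at least 1200-fold higher number from compound 1 to compound 3 (3.11 log units; beyond the scatter). The pair of compounds 2 and 3 gives a step that the two limits leave unreadable from compound 2 to compound 3 because the limit of > 10000 nM in this assay, at which 2 of the 3 values shown sit, holds both values.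

Compound 4, `CCS(=O)(=O)c1cc(C#N)cc(-c2ccc3ccc(C)nc3c2)c1`, keeps the cyano and instead carries an added group: ethylsulfonyl in place of hydrogen on an aromatic carbon. For the measured compounds named here, no measured step adds a group while leaving the cyano in place, so the two large steps speak only to the cyano itself and bear on this change indirectly. The expectation is therefore a small step, not far beyond the scatter, if any: compound 4 is estimated at 15 nM, range 4 nM to 60 nM. That estimate for compound 4 means a 1.9-fold higher number from compound 1 to compound 4 (0.29 log units; within the scatter).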

Compound 4, half-maximal inhibitory concentration: 1090 nM
Compound 4: middle estimate off by 73-fold (1.86 log units), on the low side; the whole stated range lies below it.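

Notes on the series: in this assay, keeping the cyano group does not by itself preserve the low number of compound 1, since adding ethylsulfonyl in place of hydrogen on an aromatic carbon, meta to a cyano group, gives a 140-fold higher number from compound 1 to compound 4 (2.15 log units; beyond the scatter). Among the compounds shown here, this is the first sign that this ring carbon, which bears hydrogen in compound 1, is sensitive to substitution, adding to the earlier finding about replacing the cyano group itself. Compound 4 still gives a plain number, 1090 nM, but nothing shown accounts for the rise.

With ethylsulfonyl the only group shown at this carbon, the step cannot be assigned to the sulfonyl or to the ethyl part. Going by these compounds, whether a methyl group, a fluorine atom or an amine at the same carbon would give a step of similar size remains open.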